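The compounds below may be only part of what the source reports. "The series", "measured", "known", "first", "only" and "open" are said of these compounds alone.

In an ADME assay on HepG2 cells (Homo sapiens) for cytotoxicity, read by luminescence, CellTiter-Glo and ATP content, with a stated time of 72 h (on this read-out higher numbers stand for an effect only at larger amounts of compound and lower numbers for an effect already at smaller amounts), three compounds sharing one core have been measured. Compound 1 `COc1cccc(CNCCCNc2ccnc3cc(C4CCCCC4)ccc23)c1O` gives 1080 nM, compound 2 `COc1cccc(CNCCCNc2ccnc3cc(-c4ccc(F)cc4)ccc23)c1O` gives 6840 nM, and compound 3 `COc1ccccc1Oc1ccc2c(NCCCNCc3cccc(OC)c3O)ccnc2c1` gives 11200 nM. The last two cannot be told apart, with a 1.6-fold higher number from compound 2 to compound 3 (0.21 log units; within the scatter), while the cyclohexyl compound stands clear of both, with a 6.3-fold higher number from compound 1 to compound 2 (0.80 log units; beyond the scatter) and a 10-fold higher number from compound 1 to compound 3 (1.02 log units; beyond the scatter).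

Compound 4 `COc1cccc(CNCCCNc2ccnc3cc(Cc4ccc(F)cc4Cl)ccc23)c1O` carries 2-chloro-4-fluorobenzyl in place of 2-methoxyphenoxy on an aromatic carbon. Going by the values given here, no measured step makes this exchange. The closest guide is the exchange between the two aromatic groups already measured, which stayed within the scatter, whereas the two steps away from cyclohexyl were modest and large. The new group resembles neither of the measured groups exactly, so its value is placed between compound 1 at 1080 nM and compound 2 at 6840 nM, towards the latter. What is expected for compound 4 is a 2.5-fold lower number from compound 3 to compound 4 (0.40 log units; beyond the scatter), a modest move to a lower number. The estimate for compound 4 is 4500 nM, with an expected range from 1500 nM to 12000 nM.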

Compound 4, half-maximal effective concentration: 2350 nM
Estimate against measurement, compound 4: 1.9-fold (0.28 log units) above; the measured number falls inside the stated range.
By their numbers in this assay, from the lowest: compound 1; then compound 4; then compounds 2 and 3 (each within the scatter of the next).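

Compound 4 shows that exchanging one aromatic-ring group for another at this position can move the number beyond the scatter: in this assay the 2-chloro-4-fluorobenzyl group gives a 4.8-fold lower number from compound 3 to compound 4 (0.68 log units; beyond the scatter) and also a 2.9-fold lower number from compound 2 to compound 4 (0.46 log units; beyond the scatter), although the two earlier aromatic groups could not be told apart. It still does not join the cyclohexyl compound (a 2.2-fold higher number from compound 1 to compound 4 (0.34 log units; beyond the scatter)), so compound 4 stands apart from all three others, and a carbon-only aromatic ring at this position no longer goes with a single level of the read-out. Nothing available explains these differences.

The compounds shown leave open how a 4-fluorobenzyl without the chlorine would compare with compound 4. They also leave open how a smaller saturated ring such as cyclopentyl, or an amine or a carboxylic acid, would read at this position.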